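A few compounds are considered here, and "the series" means these few. Any claim that something is new, unique, unknown or untested is made for them only; others in the source may bear on it.

Three compounds have so far been measured in a functional assay on SMMC-7721 cells (Homo sapiens) for inhibition, read by MTT assay, with a stated time of 72 h, tested at 25 uM; on this read-out lower numbers stand for less inhibition and higher numbers for more inhibition at the one concentration tested (going by the name of the read-out):

Compound 1 `CCc1nn(C)c(CO/N=C/c2c(C)nn(C)c2Oc2ccccc2F)c1Cl`: < 80%, a limit of the assay.
Compound 2 `CCc1nn(C)c(CO/N=C/c2c(C)nn(C)c2Oc2cccc(Cl)c2)c1Cl`: < 80%, a limit of the assay.
Compound 3 `CCc1nn(C)c(CO/N=C/c2c(C)nn(C)c2Oc2ccc(C)cc2)c1Cl`: < 80%, a limit of the assay.

Compound 3 therefore stands at the limit of this assay, and no number separates it from the other two, since (the limit of < 80% in this assay, at which 3 of the 3 values shown sit). The steps among the measured compounds are accordingly not readable: a step that the two limits leave unreadable from compound 1 to compound 2, a step that the two limits leave unreadable from compound 1 to compound 3 and a step that the two limits leave unreadable from compound 2 to compound 3. Compound 4 `CCc1nn(C)c(CO/N=C/c2c(C)nn(C)c2Oc2ccccc2OC)c1Cl` has not yet been measured. It differs from compound 3 in one place: 2-methoxyphenyl in place of 4-methylphenyl on an oxygen on an aromatic ring. For the measured compounds named here, none of the measured steps gives a readable size for a change of this kind, so there is no ground to expect a step beyond the usual scatter in this assay, in either direction. The expected step is a step that the limit leaves unreadable from compound 3 to compound 4. Compound 4 is therefore estimated to give about 40% in this assay, with a range from 0% to 80%, and most likely to be reported only as a limit again.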

Compound 4, a percentage reported as inhibition, at one concentration (the size of the read-out at that concentration, not a potency): < 80%
Compound 4: only a limit was reported (the forecaster's own chance of this, stated with the estimate: 85%); the middle value does not contradict the limit.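

In this assay compound 4 gives < 80% as a limit of the assay. For the compounds shown here, no step among compound 1, compound 2, compound 3 and compound 4 can be read, because all four values are limits: the limit of < 80% in this assay, at which 4 of the 4 values shown sit. The compounds shown leave open whether any of them differs from the others in this assay and by how much.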